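A few compounds are considered here, and "the series" means these few. Any claim that something is new, unique, unknown or untested is made for them only; others in the source may bear on it.

Working notes on the series. The shared core is kept throughout and only the aryl ring at the end of the chain is varied. Compound 1 `O=C(/C=C\c1ccccc1O)N1N=C(c2ccncc2)OC1c1c[nH]c2ccccc12` was run in an ADME assay on A549 cells (Homo sapiens) for cytotoxicity, read by MTT assay, with a stated time of 48 h; on this read-out lower numbers stand for stronger inhibition of growth and higher numbers for weaker inhibition of growth. Compound 1 gives > 30 ug/mL, which is a limit of the assay and not a number. Compound 2 `Cc1ccc(/C=C\C(=O)N2N=C(c3ccncc3)OC2c2c[nH]c3ccccc23)cc1` gives > 30 ug/mL in this assay, again a limit rather than a number. Compound 3 `O=C(/C=C\c1cccc(F)c1)N1N=C(c2ccncc2)OC1c1c[nH]c2ccccc12` gives > 30 ug/mL in this assay, also a limit. All three measured values sit at the limit of > 30 ug/mL in this assay, at which 3 of the 3 values shown sit. The step that the two limits leave unreadable from compound 1 to compound 2 cannot be read, nor can a step that the two limits leave unreadable from compound 1 to compound 3 or a step that the two limits leave unreadable from compound 2 to compound 3. Compound 2 thus stands only at a limit, and no rank among the measured compounds can be read from the numbers.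

Compound 4 `O=C(/C=C\c1ccccc1Cl)N1N=C(c2ccncc2)OC1c1c[nH]c2ccccc12` has not yet been measured in this assay. It differs from compound 2 by 2-chlorophenyl in place of 4-methylphenyl on a double-bonded chain carbon bound to a double-bonded chain carbon. Going by the values given here, none of the measured steps has a readable size, so no size can be carried over; the only bearing they have is that every aryl variation so far has stayed at the limit. The step that the limit leaves unreadable from compound 2 to compound 4 is therefore expected to be none beyond the scatter, with a limit again the most likely outcome. For compound 4 the estimate in this assay is 40 ug/mL, within 15 ug/mL to 120 ug/mL.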

Compound 4, concentration for 50% growth inhibition: > 30 ug/mL
Compound 4 was reported as a limit (the forecaster's own chance of this, stated with the estimate: 75%); the middle value is on the limit's open side.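

Going by these compounds alone, compound 4 also stands at a limit, so its steps to compound 1, compound 2 and compound 3 cannot be read and this result gives no new step: the limit of > 30 ug/mL in this assay, at which 4 of the 4 values shown sit. The compounds shown leave open whether any aryl ring at the end of the chain gives a readable value in this assay, and how large any difference between these rings would be.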